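From 2-chlorophenyl to 3-chlorophenyl amide

The compounds below may be only part of what the source reports. "The series", "measured", "known", "first", "only" and "open" are said of these compounds alone.

Measured in a functional assay on HO8910 cells (Homo sapiens) for inhibition, read by MTT assay, with a stated time of 24 h, tested at 1 ug/mL; a lower number here means less inhibition of growth, a higher number more inhibition of growth at the concentration tested:
- compound 1 (`CC(=O)SCCC(CCCCC(=O)Nc1ccccc1)SC(C)=O`) : 10.6%
- compound 2 (`CC(=O)SCCC(CCCCC(=O)Nc1ccccc1Cl)SC(C)=O`) : "not active" (no number reported)

Compound 2 has no single number in this assay. Among the compounds with values here, it was reported only as "not active" (no number reported), so no step from compound 1 to compound 2 can be sized, and the two can be compared only as they were reported.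

The next compound is compound 3 (`CC(=O)SCCC(CCCCC(=O)Nc1cccc(Cl)c1)SC(C)=O`) , which has not yet been measured. Its difference from compound 2 is 3-chlorophenyl in place of 2-chlorophenyl on an amide-type nitrogen. In words, it has 3-chlorophenyl in place of 2-chlorophenyl on an amide-type nitrogen, with the same atoms joined differently.

Within the data shown here, no measured pair here shows what a change of this kind does. The expectation therefore rests on the low reading of compound 1 at 10.6% and the report of compound 2 as "not active" (no number reported). No step beyond the usual scatter is expected in this assay, in either direction, and a report without a number would not be surprising.

The estimated value for compound 3 is 8%, with an expected range from 0% to 20%.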

Compound 3, percent growth inhibition at one concentration: "not active" (no number reported)
For compound 3 the study gives words and no number; there is nothing to compare the estimate with.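

Within the data shown here, compound 3, like compound 2, was reported in this assay only as "not active", without a number, so no step between them can be read. Nothing shown bears on this result. The compounds shown leave open how 3-chlorophenyl and 2-chlorophenyl on the amide-type nitrogen differ in growth inhibition, if they differ at all.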